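Chloro Replacing Methoxymethyl on a Prostanoid Analogue

The source may hold more compounds than are shown below. What is called first, only, known or untested is meant among the compounds shown, and "the series" means these compounds.

Compound 1 `O=C(O)CCCSCCN1C(=O)OC[C@@H]1/C=C/[C@@H](O)Cc1cccc(C(F)(F)F)c1` carries a trifluoromethyl group on its aromatic ring. In an assay on CHO cells for displacement of a labelled ligand from prostaglandin E2 receptor EP1 subtype (Mus musculus), read by scintillation counting, with a stated time of 20 min (a lower number here means a stronger inhibitor, a higher number a weaker inhibitor), compound 1 reaches only the limit > 10000 nM. Compound 2 `O=C(O)CCCSCCN1C(=O)OC[C@@H]1/C=C/[C@@H](O)Cc1cccc(-c2ccccc2)c1` has a phenyl group instead, and in this assay compound 2 likewise gives only the limit > 10000 nM. Compound 3 `COCc1cccc(C[C@H](O)/C=C/[C@H]2COC(=O)N2CCSCCCC(=O)O)c1` bears a methoxymethyl group, and in this assay compound 3 again returns only the limit > 10000 nM. Compound 3 thus stands with the others at the limit of > 10000 nM in this assay, at which 3 of the 3 values shown sit, and the steps a step that the two limits leave unreadable from compound 1 to compound 2, a step that the two limits leave unreadable from compound 1 to compound 3 and a step that the two limits leave unreadable from compound 2 to compound 3 cannot be sized. Compound 4 `O=C(O)CCCSCCN1C(=O)OC[C@@H]1/C=C/[C@@H](O)Cc1cccc(Cl)c1` differs from compound 3 by chloro in place of methoxymethyl on an aromatic carbon. Within the data shown here, none of the measured steps gives a readable size for this change. Compound 4 is therefore expected to remain at the limit as well, a step that the limit leaves unreadable from compound 3 to compound 4, with an estimated value of 15000 nM between 4000 nM and 50000 nM.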

Compound 4, inhibition constant: > 10000 nM
Compound 4 ended at the assay's limit (the forecaster's own chance of this, stated with the estimate: 75%); the middle value is on the limit's open side.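

Compound 4 joins compounds 1, 2 and 3 at the assay's limit, so no step among them can be read: the limit of > 10000 nM in this assay, at which 4 of the 4 values shown sit.

The compounds shown leave open which group on the aromatic ring, if any, would give a measurable value.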